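Removing a Methyl from a Scaffold Showing No Activity

A few compounds are considered here, and "the series" means these few. Any claim that something is new, unique, unknown or untested is made for them only; others in the source may bear on it.

Measured compounds:
- compound 1 `O=C1COc2ccc(-c3cccc(NS(=O)(=O)c4ccc(F)cc4)c3)cc2N1C1CC1`: > 40000 nM
- compound 2 `COc1ccc(N2C(=O)COc3ccc(-c4cnc5ccccc5c4)cc32)cc1`: > 40000 nM
- compound 3 `Cc1ccc(N2C(=O)COc3ccc(-c4cnc5ccccc5c4)cc32)cc1`: > 40000 nM

In a functional assay on A549 cells (Homo sapiens) for antiproliferative activity, read by MTT assay, with a stated time of 72 h (on this read-out higher numbers stand for weaker inhibition and lower numbers for stronger inhibition), compound 3 gives > 40000 nM, which is a limit of the assay rather than a measured number. Compound 1 likewise gives > 40000 nM, again only a limit. Compound 2 gives > 40000 nM, also a limit. All three therefore share the same standing, described by the limit of > 40000 nM in this assay, at which 3 of the 3 values shown sit. For the measured compounds named here, the one single-point change among them, a step that the two limits leave unreadable from compound 2 to compound 3, cannot be read because the limit of > 40000 nM in this assay, at which 3 of the 3 values shown sit, covers both of its ends.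

Compound 4 `O=C1COc2ccc(-c3cnc4ccccc4c3)cc2N1c1ccccc1` differs from compound 3 by hydrogen in place of methyl on an aromatic carbon. Going by the values given here, no measured step offers a readable size for such a change, and the only neighbouring step is itself unreadable. The expectation for compound 4 is therefore a step of a number no higher from compound 3 to compound 4 (the limit leaves the size open), meaning no movement beyond the scatter, with a substantial chance that this assay again returns only a limit. Compound 4 is expected to give about 40000 nM, within a range from 10000 nM to 100000 nM.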

Compound 4, half-maximal inhibitory concentration: > 40000 nM
Compound 4: only a limit was reported (the forecaster's own chance of this, stated with the estimate: 75%); the middle value lies on the limit itself.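

The steps between compound 2, compound 3 and compound 4 cannot be read, because all three compounds end at the same limit: the limit of > 40000 nM in this assay, at which 4 of the 4 values shown sit.

Going by these compounds, how strongly any of them acts on these cells stays open, as does whether methoxy, methyl or hydrogen at that aromatic carbon makes any difference.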